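From 3,4-Dimethoxyphenyl to Plain Phenyl in Compound 3

The source may hold more compounds than are shown below. What is called first, only, known or untested is meant among the compounds shown, and "the series" means these compounds.

Within the data shown here, compound 2 `COc1ccc(-c2ccc(-c3ccc(-c4nc5cc(C)ccc5[nH]4)cc3)cc2)cc1OC` stands lowest of the two numbers measured so far: in a functional assay on MCF7 cells (Homo sapiens) for inhibition, read by sulforhodamine B assay (on this read-out higher numbers stand for weaker inhibition of growth and lower numbers for stronger inhibition of growth), compound 2 gives 190 nM. Among the measured compounds shown here, its only measured neighbour is compound 1 `Cc1ccc2[nH]c(-c3ccc(-c4ccc(-c5ccc(N(C)C)cc5)cc4)cc3)nc2c1`, and in this assay compound 1 gives 3130 nM. For the measured compounds named here, the one step between them, a 16-fold lower number from compound 1 to compound 2 (1.22 log units; beyond the scatter), shows that the substituent on the outermost ring can shift the number a great deal. Compound 3 `Cc1ccc2[nH]c(-c3ccc(-c4ccc(-c5ccccc5)cc4)cc3)nc2c1` differs from compound 2 in one place: phenyl in place of 3,4-dimethoxyphenyl on an aromatic carbon. Going by the values given here, no measured pair shows what the bare phenyl does, so the step from compound 1 to compound 2 bears only indirectly, by showing how sensitive this position is. Since the group that gave compound 2 its low number is taken away, a weakening step of moderate size is expected for compound 3, a 5.3-fold higher number from compound 2 to compound 3 (0.72 log units; beyond the scatter). The estimate for compound 3 in this assay is 1000 nM, within a range from 250 nM to 4000 nM.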

Compound 3, concentration for 50% growth inhibition: 31600 nM
For compound 3 the middle estimate is 32-fold (1.50 log units) below the measured one; measured number outside the range, above it.
By their numbers in this assay, from the lowest: compound 2; then compound 1; then compound 3.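

The bare phenyl is not a neutral baseline at this position, since removing the methoxy groups gives a 170-fold higher number from compound 2 to compound 3 (2.22 log units; beyond the scatter) in this assay, far more than the substituent exchange between the two earlier compounds. Even the dimethylamino group of the weaker earlier compound counts for something: replacing it with hydrogen gives a 10-fold higher number from compound 1 to compound 3 (1.00 log units; beyond the scatter), so among these three compounds both substituted outer rings give lower numbers than the unsubstituted one, and compound 3 stands as the weakest. Nothing available here accounts for the size of these steps.

Going by these compounds, it remains open whether a single methoxy group would retain the low number of compound 2 or whether both are needed. Also open, on these data alone, is how a hydroxyl group, a primary amine or a carboxylic acid would fare on the same ring.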